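A Benzyl Substituent Swap and Expected Tolerance in Cells

The source may hold more compounds than are shown below. What is called first, only, known or untested is meant among the compounds shown, and "the series" means these compounds.

Compound 2 `Cc1ccc2[nH]c(=O)c(CN(Cc3ccc(N(C)C)cc3)Cc3ccc(C(C)(C)C)cc3)cc2c1` and compound 1 `Cc1ccc2[nH]c(=O)c(CN(Cc3ccc(OC(C)C)cc3)Cc3ccc(C(C)(C)C)cc3)cc2c1` share one core and differ only in one group on a benzyl ring. In a toxicity assay on MDCK cells (Canis lupus familiaris) for cytotoxicity, read by crystal violet staining, with a stated time of 48 h (a lower number here means that less compound is tolerated, a higher number that more compound is tolerated), compound 1 gives only a limit, > 5000 nM. In this assay compound 2 likewise gives only a limit, > 5000 nM. The step that the two limits leave unreadable from compound 1 to compound 2 is therefore not readable in size, and the limit of > 5000 nM in this assay, at which 2 of the 2 values shown sit, describes where both values sit. Compound 3 `Cc1ccc2[nH]c(=O)c(CN(Cc3ccc(SC(F)(F)F)cc3)Cc3ccc(C(C)(C)C)cc3)cc2c1` arises from compound 2 by the change ((trifluoromethyl)sulfanyl in place of dimethylamino on an aromatic carbon). Among the compounds with values here, no measured step offers a readable size, so the only guide is that both measured compounds sit at the limit. For compound 3 the expected step that the limit leaves unreadable from compound 2 to compound 3 is therefore no movement beyond the scatter in either direction. Compound 3 is accordingly expected to give about 8000 nM in this assay, most likely again reported only as a limit, within a range from 3000 nM to 30000 nM.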

Compound 3, half-maximal cytotoxic concentration: > 5000 nM
Compound 3: no number, only a limit (the forecaster's own chance of this, stated with the estimate: 80%); the middle value does not contradict the limit.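

In this assay compound 3 gives only a limit, > 5000 nM. The steps among compound 1, compound 2 and compound 3 therefore cannot be read in size: the limit of > 5000 nM in this assay, at which 3 of the 3 values shown sit.

The compounds shown leave open how much of each compound the cells actually tolerate, and whether swapping the benzyl substituent changes that at all.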